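The source may report more compounds than this note shows. Statements on the series, on what has been measured and on what is new or still open speak of the compounds shown alone.

Compound 1 `CCCCCc1ccc(-c2cc3cn([C@H]4C[C@H](OC(=O)[C@@H](NC(=O)[C@@H]5CCCN5C(=O)[C@@H](N)C(C)C)C(C)C)[C@@H](COC(=O)[C@@H](NC(=O)[C@@H]5CCCN5C(=O)[C@@H](N)C(C)C)C(C)C)O4)c(=O)nc3o2)cc1`: > 5000 nM
Compound 2 `CCCCCc1ccc(-c2cc3cn([C@H]4C[C@H](O)[C@@H](COC(=O)[C@@H](NC(=O)[C@@H]5CCCN5C(=O)[C@@H](N)CC(N)=O)C(C)C)O4)c(=O)nc3o2)cc1`: > 5000 nM

In an ADME assay on HEL cells (Homo sapiens) for cytotoxicity (a higher number here means that more compound is tolerated, a lower number that less compound is tolerated), compound 1 reaches only a limit, > 5000 nM. Compound 2 likewise reaches only a limit in this assay, namely > 5000 nM. Among the measured compounds shown here, both sit at the limit of > 5000 nM in this assay, at which 2 of the 2 values shown sit, so compound 2 stands at the limit and no measured step between compounds exists here. Compound 3 `CCCCCc1ccc(-c2cc3cn([C@H]4C[C@H](O)[C@@H](COC(=O)[C@@H](NC(=O)[C@@H]5CCCN5C(=O)[C@@H](N)CC(=O)O)C(C)C)O4)c(=O)nc3o2)cc1` differs from compound 2 by hydroxy in place of amino on a carbonyl carbon. Nothing measured shows what this change does in this assay, so for compound 3 no step beyond the scatter is expected, estimated as a number no higher from compound 2 to compound 3 (the limit leaves the size open). Compound 3 is therefore expected at 5000 nM, between 2500 nM and 10000 nM, most likely again as a limit.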

Compound 3, minimum cytotoxic concentration in the HEL assay: > 5000 nM
Compound 3: only a limit was reported (the forecaster's own chance of this, stated with the estimate: 85%); the middle value sits exactly at the limit.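

Among the compounds shown here, in the HEL assay compound 2 and compound 3 both stand at a limit, so no step between them can be read. In a physicochemical assay for solubility, with a stated time of 24 h (a higher number here means a more soluble compound, a lower number a less soluble compound), compound 2 gives 39000 ug/mL and compound 3 gives 15000 ug/mL and that is a 2.6-fold lower number from compound 2 to compound 3 (0.41 log units; beyond the scatter) for hydroxy in place of amino on a carbonyl carbon. From the compounds shown here alone, how much of either compound is tolerated in the HEL assay stays open.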